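Aryl methoxy replaced by methyl in the series

This account rests on a few compounds, and the source may have more. Where it says the series, first, only, none or still open, it means among the compounds named here.

Compound 1 `COc1ccc(-c2cn(C[C@H]3c4c(ccc(O)c4C)[C@@H]4CC[C@@]5(C)C[C@]43CC5=O)nn2)cc1` carries a 4-methoxyphenyl group on the shared core. In a functional assay on SW480 cells (Homo sapiens) for cytotoxicity, read by MTT assay, with a stated time of 4 days (on this read-out higher numbers stand for weaker inhibition and lower numbers for stronger inhibition), compound 1 gives > 20000 nM, which is a limit of the assay and not a number. Compound 1 therefore stands at the limit of > 20000 nM in this assay, at which 1 of the 2 values shown sits. Among the compounds with values here, compound 2 `C=C1C(=O)[C@]23C[C@@]1(O)CC[C@H]2c1ccc(O)c(C)c1[C@@H]3Cn1cc(-c2ccc(C(F)(F)F)cc2)nn1`, built on a differently substituted core and bearing a trifluoromethyl-substituted phenyl, is the only other measured member. In this assay compound 2 gives 370 nM. The two measured compounds differ in more than one place, so no single step can be read between them.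

Compound 3 `Cc1ccc(-c2cn(C[C@H]3c4c(ccc(O)c4C)[C@@H]4CC[C@@]5(C)C[C@]43CC5=O)nn2)cc1` differs from compound 1 by methyl in place of methoxy on an aromatic carbon. With compound 1 at the limit, no direction is fixed by the numbers; a change of this size is expected to move the value little beyond the scatter, most likely leaving it near the limit. Compound 3 is expected to give about 15000 nM, between 3000 nM and 40000 nM. The expected step is an at least 1.3-fold lower number from compound 1 to compound 3 (0.12 log units; that floor lies within the scatter).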

Compound 3, half-maximal inhibitory concentration: > 20000 nM
Compound 3: no number, only a limit (the forecaster's own chance of this, stated with the estimate: 55%); middle value at least 1.3-fold (0.12 log units) from the limit.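

In this assay compound 1 and compound 3 both give only a limit, and no step can be read between them. Still open, from the compounds shown here alone, is how far each compound lies past that limit, and whether going from 4-methoxyphenyl to 4-methylphenyl changes the value at all.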